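The compounds below may be only part of what the source reports. "The series", "measured", "known", "first", "only" and "open" are said of these compounds alone.

Measured so far:
compound 1 `C=CC1=C(C(=O)NCc2ccccc2)C(c2ccc(OC)c(OC)c2)OC1` — in a functional assay on QGY7701 cells (Homo sapiens) for cytotoxicity, read by MTT assay, with a stated time of 24 h (on this read-out higher numbers stand for weaker inhibition and lower numbers for stronger inhibition), compound 1 gives > 100000 nM, a limit of the assay.
compound 2 `C=CC1=C(C(=O)NCc2ccccc2)C(c2ccc(OC)cc2)OC1` — in this assay compound 2 gives > 100000 nM, likewise a limit.
compound 3 `C=CC1=C(C(=O)NCCC)C(c2ccc(Cl)c(Cl)c2)OC1` — in this assay compound 3 gives 31300 nM.

Compound 2 stands at the assay limit, where compound 1 also sits (the limit of > 100000 nM in this assay, at which 2 of the 3 values shown sit); the step that the two limits leave unreadable from compound 1 to compound 2 therefore cannot be read. For the measured compounds named here, compound 3, with a different amide substituent and a different aromatic ring, carries the only numbered value. The next compound, compound 4 `C=CC1=C(C(=O)NC2CCCCC2)C(c2ccc(OC)cc2)OC1`, differs from compound 2 by cyclohexyl in place of benzyl on an amide-type nitrogen. Going by the values given here, no measured step touches this amide nitrogen, so the size and direction of the change are open. The step expected in this assay is a number no higher from compound 2 to compound 4 (the limit leaves the size open), resting on nothing more than the limit already given for compound 2. Compound 4 is therefore estimated at 100000 nM, within 30000 nM to 300000 nM, with a fair chance that only a limit is again reported.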

Compound 4, half-maximal inhibitory concentration: > 100000 nM
Compound 4 was reported as a limit; the forecaster's own chance of this, stated with the estimate: 55%; the middle value lies on the limit itself.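

In this assay compound 4 gives > 100000 nM, a limit and not a number, and compound 2 is also reported only as a limit, so no step between the two can be read: the limit of > 100000 nM in this assay, at which 3 of the 4 values shown sit.

The compounds shown leave open what cyclohexyl in place of benzyl on an amide-type nitrogen does to the value.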